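Exchanging methyl for chlorine on a urea aryl group

The source may hold more compounds than are shown below. What is called first, only, known or untested is meant among the compounds shown, and "the series" means these compounds.

Measured in a functional assay on HeLa cells (Homo sapiens) for inhibition, read by CCK-8 assay, with a stated time of 48 h; a lower number here means a stronger inhibitor, a higher number a weaker inhibitor:
- Compound 1 `COc1ccc(Oc2ccc(C(C)C)cc2-c2ccsc2S(=O)(=O)NCCNC(=S)Nc2ccc([N+](=O)[O-])cc2)cc1OC`: 11900 nM
- Compound 2 `COc1ccc(NC(=O)NCCNS(=O)(=O)c2ccc(-c3ccccc3OCc3ccccc3)s2)cc1`: > 50000 nM (a limit of the assay)
- Compound 3 `Cc1cc(C)cc(NC(=O)NCCNS(=O)(=O)c2ccc(-c3ccccc3Oc3ccc([N+](=O)[O-])c([N+](=O)[O-])c3)s2)c1`: 12000 nM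

In this assay compound 3 gives 12000 nM and compound 1 gives 11900 nM, two values within the scatter of each other. Compound 2 reaches only a limit, > 50000 nM. Compound 4 `O=C(NCCNS(=O)(=O)c1ccc(-c2ccccc2Oc2ccc([N+](=O)[O-])c([N+](=O)[O-])c2)s1)Nc1cc(Cl)cc(Cl)c1` carries 3,5-dichlorophenyl in place of the 3,5-dimethylphenyl of compound 3, on an amide-type nitrogen (3,5-dichlorophenyl in place of 3,5-dimethylphenyl on an amide-type nitrogen). Going by the values given here, no measured pair differs in one place only, so the exchange cannot be sized directly. The expected step of a 1.2-fold lower number from compound 3 to compound 4 (0.08 log units; within the scatter) is small, within the scatter or slightly beyond it, towards a lower number. Compound 4 is estimated at 10000 nM, with an expected range of 4500 nM to 25000 nM.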

Compound 4, half-maximal inhibitory concentration: > 20000 nM
Compound 4: no number, only a limit (the forecaster's own chance of this, stated with the estimate: 12%); at least 2.0-fold (0.30 log units) between middle value and limit.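

In this assay, going by these compounds alone, the exchange on the amide-type nitrogen gives the first direct reading at this position: an at least 1.6-fold higher number from compound 3 to compound 4 (0.22 log units; that floor lies within the scatter). This step gives no sign of the lower number that 3,5-dichlorophenyl might have brought, yet its floor does not separate compound 4 from compound 3. The true size of the step stays unknown because compound 4 reaches only a limit: the limit of > 20000 nM in this assay, at which 1 of the 4 values shown sits.

The compounds shown leave open how a 3,5-difluorophenyl or an unsubstituted phenyl on this nitrogen would read. They also leave open whether any group here gives a number well below that of compound 3.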